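The source may hold more compounds than are shown below. What is called first, only, known or untested is meant among the compounds shown, and "the series" means these compounds.

Compound 1 `O=S(=O)(Nc1ccc2oc(-c3ccccc3)nc2c1)c1ccc(Cl)c(Cl)c1`: > 63000 nM
Compound 2 `COc1ccc(Cl)cc1S(=O)(=O)Nc1ccc(-c2nc3ccccc3o2)cc1`: > 63000 nM
Compound 3 `C=Cc1ccc(S(=O)(=O)Nc2ccc3oc(-c4ccccc4)nc3c2)cc1`: > 63000 nM

Of the compounds shown here, three have been tested in an assay on isolated protein for inhibition of malate dehydrogenase, mitochondrial (Sus scrofa), with stated times of 45 min and 30 min; on this read-out higher numbers stand for weaker inhibition and lower numbers for stronger inhibition. Compound 1 gives > 63000 nM, which is a limit of the assay and not a measured number. Compound 3 gives > 63000 nM, again a limit. Compound 2 gives > 63000 nM, also a limit. Compound 2 therefore stands exactly where the other two stand, at the limit (the limit of > 63000 nM in this assay, at which 3 of the 3 values shown sit), so none of the three can be ordered against the others.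

Among the compounds with values here, the only step that joins two measured compounds through a single change is a step that the two limits leave unreadable from compound 1 to compound 3, a swap of the group on the sulfonyl sulfur. It concerns the same position as the step to compound 4, but its size cannot be read.

Compound 4 `COc1cccc(S(=O)(=O)Nc2ccc(-c3nc4ccccc4o3)cc2)c1` differs from compound 2 in one place: 3-methoxyphenyl in place of 5-chloro-2-methoxyphenyl on a sulfonyl sulfur. Within the data shown here, no measured step gives a usable size for such a change, and the starting point sits at the limit. The expected step is a step that the limit leaves unreadable from compound 2 to compound 4, none beyond the scatter. Compound 4 is therefore estimated at 100000 nM, within 50000 nM to 500000 nM, and most probably reported only as a limit once more.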

Compound 4, half-maximal inhibitory concentration: > 63000 nM
Compound 4 ended at the assay's limit; the forecaster's own chance of this, stated with the estimate: 85%; the middle value is on the limit's open side.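

Within the data shown here, compound 2 and compound 4 both stand at a limit of the assay, so the swap of 5-chloro-2-methoxyphenyl for 3-methoxyphenyl on the sulfonyl sulfur gives no step that can be read. What stays open is how strongly any of these compounds inhibits in this assay and whether any change on the sulfonyl sulfur matters, with every value alike: the limit of > 63000 nM in this assay, at which 4 of the 4 values shown sit.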